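Tert-butoxycarbonyl in place of methyl on the ring nitrogen

A few compounds are considered here, and "the series" means these few. Any claim that something is new, unique, unknown or untested is made for them only; others in the source may bear on it.

Compound 3 `CN1CCc2c(sc(NC(=O)c3ccc(OCc4ccccc4)cc3)c2C(N)=O)C1` gives the highest of the three numbers in an ADME assay on RAW264.7 cells (Mus musculus) for cytotoxicity, read by MTT assay, with a stated time of 48 h, tested at 50 uM (a lower number here means less inhibition, a higher number more inhibition at the concentration tested (going by the name of the read-out)), with 37.6%; compound 1 `CC(C)(C)OC(=O)N1CCc2c(sc(NC(=O)c3ccc(Oc4ccccc4)cc3)c2C(N)=O)C1` gives 26.9% and compound 2 `CC(=O)N1CCc2c(sc(NC(=O)c3ccc(OCc4ccccc4)cc3)c2C(N)=O)C1` gives 11.6%. Among the measured compounds shown here, the one step measured at this position, a number 26 percentage points higher from compound 2 to compound 3 (beyond the scatter), runs from an acyl group to methyl. Compound 4 `CC(C)(C)OC(=O)N1CCc2c(sc(NC(=O)c3ccc(OCc4ccccc4)cc3)c2C(N)=O)C1` carries tert-butoxycarbonyl in place of methyl on an amine nitrogen in a ring, the reverse sense of that step, towards a carbonyl-bearing group, while compound 1 shows what a tert-butoxycarbonyl on this nitrogen gives with a different linker. A downward step is therefore expected in this assay, estimated as a number 17.6 percentage points lower from compound 3 to compound 4 (beyond the scatter). For compound 4 the expected value is 20%, with a range of 8% to 34%.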

Compound 4, a percentage reported as inhibition, at one concentration (the size of the read-out at that concentration, not a potency): 52.1%
Beside the measured number, compound 4's estimate is 32.1 percentage points below it; measured number outside the range, above it.
By their numbers in this assay, from the lowest: compound 2; then compound 1; then compound 3; then compound 4.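

At the amine nitrogen in a ring in this assay a carbonyl-bearing group does not by itself give the lower number: tert-butoxycarbonyl in place of methyl gives a number 14.5 percentage points higher from compound 3 to compound 4 (beyond the scatter) and so reverses the direction of the acetyl comparison. Among the carbonyl-bearing groups, tert-butoxy in place of methyl on the carbonyl carbon gives a number 40.5 percentage points higher from compound 2 to compound 4 (beyond the scatter) and thus separates the two compounds widely. The oxygen substituent also counts, since benzyl in place of phenyl gives a number 25.2 percentage points higher from compound 1 to compound 4 (beyond the scatter) with tert-butoxycarbonyl kept on the nitrogen.

No available evidence explains these steps. Going by these compounds, how a free amine or a longer acyl chain on this nitrogen would stand remains open.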